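The source may hold more compounds than are shown below. What is called first, only, known or untested is meant among the compounds shown, and "the series" means these compounds.

Working notes on the series. Compound 1 `COc1ccc(-c2[nH]c3ccccc3c2/C=C(\C#N)S(=O)(=O)c2ccccc2)cc1` is the reference point. In a functional assay on OVCAR-3 cells (Homo sapiens) for inhibition, read by sulforhodamine B assay, with a stated time of 48 h (on this read-out higher numbers stand for weaker inhibition of growth and lower numbers for stronger inhibition of growth), compound 1 gives 244 nM. Compound 2 `CCOC(=O)C(=Cc1c(-c2ccccc2)[nH]c2ccccc12)C(=O)OCC`, a diester analogue of the same indole-bearing type, gives 4200 nM in this assay. Among the compounds with values here, of the two numbers available, compound 1 holds the lower one, and the gap to compound 2 is well beyond the scatter of repeated measurements; no single-point step between these two is defined, so only the two values themselves can be compared.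

Compound 3 `COc1ccc(-c2[nH]c3ccc(OC)cc3c2/C=C(\C#N)S(=O)(=O)c2ccccc2)cc1` is not yet measured. It differs from compound 1 by methoxy in place of hydrogen on an aromatic carbon, described as methoxy in place of hydrogen on an aromatic carbon. Within the data shown here, no measured pair in this set isolates that change, so the expected step in this assay rests on the retained core alone. Compound 3 is expected to sit close to compound 1, with the step of a 1.2-fold lower number from compound 1 to compound 3 (0.09 log units; within the scatter) estimated to fall within the scatter. The estimate for compound 3 is 200 nM, with a range from 60 nM to 700 nM.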

Compound 3, concentration for 50% growth inhibition: 359 nM
Beside the measured number, compound 3's estimate is 1.8-fold (0.25 log units) below it, and the stated range covers the measured number.
By their numbers in this assay, from the lowest: compounds 1 and 3 (each within the scatter of the next); then compound 2.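

In this assay the step is a 1.5-fold higher number from compound 1 to compound 3 (0.17 log units; within the scatter) for methoxy in place of hydrogen on an aromatic carbon of the six-membered aromatic ring of carbon only, part of a fused or bridged system of two rings. This position on the core of compound 1 therefore accepts a methoxy with compound 1 and compound 3 lying within the scatter of each other, something compound 1 and compound 2 could not show, as they differ in more than one place. Nothing measured here gives a reason for this result.

From the compounds shown here alone, whether a hydroxyl, a chlorine or an amine at the same position would also stay within the scatter remains open. So does whether a methoxy on the other carbons of this ring would give the same outcome.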